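Back from the limit: one chloro instead of three

This account rests on a few compounds, and the source may have more. Where it says the series, first, only, none or still open, it means among the compounds named here.

In a functional assay on A549 cells (Homo sapiens) for antiproliferative activity, read by MTT assay, with a stated time of 72 h (a lower number here means a stronger inhibitor, a higher number a weaker inhibitor), compound 1 `NC1=NC2(CCSCC2)N(OCCCOc2ccc(Cl)c(Cl)c2)C(N)=N1` gives 1 nM, and compound 2 `NC1=NC2(CCSCC2)N(OCCCOc2cccc(Cl)c2)C(N)=N1` gives 60 nM. Compound 3 `NC1=NC2(CCSCC2)N(OCCCOc2cc(Cl)c(Cl)cc2Cl)C(N)=N1` has only a limit, > 100000 nM. Compound 4 `NC1=NC2(CCSCC2)N(OCCCOc2ccccc2Cl)C(N)=N1` has 2-chlorophenyl in place of the 2,4,5-trichlorophenyl of compound 3 (2-chlorophenyl in place of 2,4,5-trichlorophenyl on an oxygen on a saturated carbon). Changes in chloro substitution alone have produced large steps here: a 60-fold higher number from compound 1 to compound 2 (1.78 log units; beyond the scatter), an at least 100000-fold higher number from compound 1 to compound 3 (5.00 log units; beyond the scatter) and an at least 1600-fold higher number from compound 2 to compound 3 (3.22 log units; beyond the scatter). The last step is the closest guide, since it also links a single-chloro ring with the 2,4,5-trichlorophenyl ring. Compound 4 also carries one chloro, but in a different place from compound 2, so the expectation is loose. A large fall in this assay is expected, an at least 330-fold lower number from compound 3 to compound 4 (2.52 log units; beyond the scatter). The estimate for compound 4 is 300 nM, within a range of 8 nM to 10000 nM.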

Compound 4, half-maximal inhibitory concentration: 80 nM
Compound 4: the middle estimate sits 3.8-fold (0.57 log units) above what was measured; low and high end bracket the measured number.
By their numbers in this assay, from the lowest: compound 1; then compounds 2 and 4 (each within the scatter of the next). At a limit, above all of these: compound 3.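

In this assay, 2-chlorophenyl brings the activity back from the 2,4,5-trichlorophenyl ring (an at least 1200-fold lower number from compound 3 to compound 4 (3.09 log units; beyond the scatter)). From the compounds shown here alone, compound 3 gives only a limit, not a number, so the true size of that step is unknown: the limit of > 100000 nM in this assay, at which 1 of the 4 values shown sits. The two rings with a single chloro cannot be told apart (a 1.3-fold higher number from compound 2 to compound 4 (0.12 log units; within the scatter)), while a clear gap remains to the 3,4-dichlorophenyl ring (an 80-fold higher number from compound 1 to compound 4 (1.90 log units; beyond the scatter)).

Going by these compounds, what a fluoro or methoxy group in place of the chloro would give stays open. So does the effect of a longer chain leading to the ring.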